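A Phenyl in Place of Methoxy on the Shared Core

The source may hold more compounds than are shown below. What is called first, only, known or untested is meant among the compounds shown, and "the series" means these compounds.

Among the measured compounds shown here, compound 2 `COc1ccc(C(=O)/C=C/CCc2ccccc2)cc1` is one of two compounds measured in a functional assay on HEK293 cells for antagonist activity at G-protein coupled receptor 52 (Homo sapiens), read by cAMP accumulation, with stated times of 15 min and 30 min; a lower number here means a stronger inhibitor, a higher number a weaker inhibitor; compound 2 gives 3870 nM. For the measured compounds named here, the only neighbour, compound 1 `Cc1ccc(C(=O)/C=C/CCc2ccccc2)cc1`, gives 3020 nM in this assay, and the single recorded step, a 1.3-fold higher number from compound 1 to compound 2 (0.11 log units; within the scatter), is methoxy in place of methyl on an aromatic carbon. Compound 2 thus sits at one end of the two numbers, but the gap to compound 1 lies within the scatter, so the two cannot be ordered. Compound 3 `O=C(/C=C/CCc1ccccc1)c1ccc(-c2ccccc2)cc1` differs from compound 2 by phenyl in place of methoxy on an aromatic carbon, para to a large group. Going by the values given here, no measured step exchanges a methoxy for a phenyl, and the one step at that position stayed within the scatter. Compound 3 is therefore expected to move by only a 1.3-fold lower number from compound 2 to compound 3 (0.11 log units; within the scatter) in this assay, nothing beyond the scatter. Compound 3 is estimated at 3000 nM, in a range from 900 nM to 10000 nM.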

Compound 3, half-maximal inhibitory concentration: 7640 nM
Estimate against measurement, compound 3: 2.5-fold (0.41 log units) below, within the range that was stated.
By their numbers in this assay, from the lowest: compounds 1, 2 and 3 (each within the scatter of the next, the first and the last beyond it).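

In this assay this position, on an aromatic carbon para to a large group, now carries a whole ring, and phenyl in place of methoxy gives a 2.0-fold higher number from compound 2 to compound 3 (0.30 log units; within the scatter) so that exchange alone cannot be told from no change. Phenyl in place of methyl gives a 2.5-fold higher number from compound 1 to compound 3 (0.40 log units; beyond the scatter) and this modest step is the first at the position to pass beyond the scatter. The same phenyl thus reads differently against the two smaller groups, beyond the scatter against methyl and within it against methoxy.

The compounds shown leave open whether an amine or a carboxylic acid at this position would stay close to these numbers. They also leave open whether a ring other than phenyl would do the same. No evidence is available to explain the difference between the two steps.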